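Replacing quinolin-4-yl on the carbonyl carbon of compound 2

This account rests on a few compounds, and the source may have more. Where it says the series, first, only, none or still open, it means among the compounds named here.

In a functional assay on NCI-H460 cells (Homo sapiens) for antiproliferative activity (a lower number here means a stronger inhibitor, a higher number a weaker inhibitor), compound 1 (`COc1ccc(S(=O)(=O)Oc2ccccc2NC(=O)c2ccncc2)cc1`) gives 55 nM as its half-maximal inhibitory concentration. Compound 2 (`COc1ccc(S(=O)(=O)Oc2ccccc2NC(=O)c2ccnc3ccccc23)cc1`) reads > 10000 nM in this assay and this is only a limit. Among the compounds with values here, the one measured step bearing on the change is large: an at least 180-fold higher number from compound 1 to compound 2 (2.25 log units; beyond the scatter) with quinolin-4-yl in place of pyridin-4-yl on a carbonyl carbon. Compound 3 (`COc1ccc(S(=O)(=O)Oc2ccccc2NC(=O)c2ccc(N(C)C)cc2)cc1`) has 4-(dimethylamino)phenyl in place of quinolin-4-yl on a carbonyl carbon and does not return pyridin-4-yl. A partial recovery toward a lower number is therefore expected, with an estimated at least 5.0-fold lower number from compound 2 to compound 3 (0.69 log units; beyond the scatter) of moderate size. For compound 3 the estimated value is 2000 nM with an expected range from 200 nM to 10000 nM.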

Compound 3, half-maximal inhibitory concentration: > 10000 nM
Compound 3 gave a limit, no number (the forecaster's own chance of this, stated with the estimate: 35%); middle value at least 5.0-fold (0.69 log units) away from the limit.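

Compound 3 reads > 10000 nM in this assay, and this is a limit, not a number. The step between compound 2 and compound 3 cannot be read. The change from pyridin-4-yl to 4-(dimethylamino)phenyl on the carbonyl carbon gives an at least 180-fold higher number from compound 1 to compound 3 (2.25 log units; beyond the scatter), so the loss at this position is no longer tied to quinolin-4-yl alone, and pyridin-4-yl remains the only group shown here with a measured value.

On these data alone, whether pyridin-3-yl or a plain phenyl at this position would give a measured value stays open. So does how far apart compound 2 and compound 3 really lie.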